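This account rests on a few compounds, and the source may have more. Where it says the series, first, only, none or still open, it means among the compounds named here.

Among the measured compounds shown here, compound 3 `CCCN(C)c1nc(Cc2c(F)cccc2F)c(C)c(=O)[nH]1` is one of three compounds measured in an ADME assay on MT4 cells (Homo sapiens) for cytotoxicity, read by MTT assay, with a stated time of 4 days; on this read-out higher numbers stand for lower toxicity in this test and lower numbers for higher toxicity in this test. Its value is a limit of the assay: in this assay compound 3 gives > 81000 nM. Compound 1 `CCCN(C)c1nc(Cc2c(F)cccc2F)cc(=O)[nH]1` gives 85000 nM in this assay. Compound 2 `CN1CCN(c2nc(Cc3c(F)cccc3F)cc(=O)[nH]2)CC1` also stops at a limit, giving > 78000 nM in this assay. Two steps between these compounds were followed: a step that the limit leaves unreadable from compound 1 to compound 3, and a step that the limit leaves unreadable from compound 1 to compound 2. For the measured compounds named here, compound 3 therefore stands at the upper edge of what the assay could read, and no measured step separates it from the other two.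

Compound 4 `Cc1c(Cc2c(F)cccc2F)nc(N2CCC(C)CC2)[nH]c1=O` differs from compound 3 in one place: 4-methylpiperidin-1-yl in place of methyl(propyl)amino on an aromatic carbon. The nearest comparison is the step from compound 1 to compound 2 , where the same methyl(propyl)amino gave way to a ring amine, 4-methylpiperazin-1-yl; its size could not be read because of the limit of > 78000 nM in this assay, at which 1 of the 3 values shown sits. With both measured steps unreadable, no step beyond the scatter is expected for compound 4: an at least 1.0-fold lower number from compound 3 to compound 4 (0.00 log units; that floor lies within the scatter). Compound 4 is thus estimated at 80000 nM, between 50000 nM and 130000 nM, and the assay is expected to report only a limit again.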

Compound 4, half-maximal cytotoxic concentration: > 75000 nM
Compound 4 gave a limit, no number; the forecaster's own chance of this, stated with the estimate: 70%; the middle value is on the limit's open side.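

In this assay compound 4 gives > 75000 nM, which is a limit of the assay. The step between compound 3 and compound 4 cannot be read, as both values are limits. The compounds shown leave open whether either ring amine or the added methyl changes this read-out.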